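A few compounds are considered here, and "the series" means these few. Any claim that something is new, unique, unknown or untested is made for them only; others in the source may bear on it.

Measured in a functional assay on PC-3 cells (Homo sapiens) for antiproliferative activity, read by WST assay, with a stated time of 72 h; on this read-out higher numbers stand for an effect only at larger amounts of compound and lower numbers for an effect already at smaller amounts:
- compound 1 `CCCCCCCC/C=C\c1c(C)c(/C=C\CCCCCCCC)c2[n+](c1C)CCC2`: 1.1 uM
- compound 2 `CCCCCCCC/C=C\c1c(C)c(/C=C/CCCCCCCC)c(C)[n+]2c1CCC2`: 0.7 uM
- compound 3 `CCCCCCCC/C=C/c1c(C)cc(C)[n+]2c1CCC2`: 0.6 uM

All three values lie within the usual scatter of one another, so compound 3, at 0.6 uM, cannot be separated from compound 1 or compound 2. The next compound to be tested is compound 4 `CCCCCCCC/C=C\c1c(C)cc(C)[n+]2c1CCC2`. Its relation to compound 3 is simple: the two compounds have the same atoms and bonds and differ only in configuration as drawn: 1 of 1 stereo elements differ; a double bond is drawn E in compound 3 and Z in compound 4. Among the compounds with values here, only one measured step is of this kind, and there a double bond is drawn Z in compound 1 and E in compound 2. That step is a 1.6-fold lower number from compound 1 to compound 2 (0.20 log units; within the scatter). The change now in question runs the other way, from E to Z, so any shift would be expected toward a higher number in this assay. Within the data shown here, with compound 2 as the sole precedent, however, no step beyond the scatter is expected. The estimate means a 1.3-fold higher number from compound 3 to compound 4 (0.12 log units; within the scatter), an expected step within the scatter. For compound 4 the expected value is 0.8 uM, with an estimated range from 0.35 uM to 1.8 uM.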

Compound 4, concentration for half-maximal effect: 0.2 uM
Compound 4: middle estimate off by 4.0-fold (0.60 log units), on the high side; measured number below the stated range.
By their numbers in this assay, from the lowest: compound 4; then compounds 3, 2 and 1 (each within the scatter of the next).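

In this assay, within the data shown here, the configuration of the double bond in the dec-1-en-1-yl chain now makes a readable difference: with one chain on the core, going from E to Z gives a step beyond the scatter (a 3.0-fold lower number from compound 3 to compound 4 (0.48 log units; beyond the scatter)), whereas the only earlier change of configuration, Z to E in a compound with two chains, stayed within it (a 1.6-fold lower number from compound 1 to compound 2 (0.20 log units; within the scatter)). Compound 4, with hydrogen in place of the second chain, also stands apart from both two-chain compounds (a 3.5-fold lower number from compound 2 to compound 4 (0.54 log units; beyond the scatter)) (a 5.5-fold lower number from compound 1 to compound 4 (0.74 log units; beyond the scatter)). Compound 3 goes against any rule based on the number of chains alone: it also carries one chain, yet it stays within the scatter of compound 1 and compound 2.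

The compounds shown leave open whether the Z chain keeps this lower number when it is replaced by a shorter or longer chain. They also leave open what a saturated decyl chain, or an amine at the end of the chain, would do.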